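Methoxy-to-hydroxy step on the methylphenyl ring, compound 3 to 4

A few compounds are considered here, and "the series" means these few. Any claim that something is new, unique, unknown or untested is made for them only; others in the source may bear on it.

Measured so far in a functional assay on LOX IMVI cells (Homo sapiens) for inhibition, read by sulforhodamine B assay, with a stated time of 48 h; on this read-out lower numbers stand for stronger inhibition of growth and higher numbers for weaker inhibition of growth:
- compound 1, `COc1cc(C)cc(-c2c(-c3ccnc(-c4ccc(C(C)=O)cc4)c3)cnn2CC#N)c1`, gives 3390 nM
- compound 2, `Cc1cc(O)cc(-c2nn(CC#N)cc2-c2ccnc(-c3ccc(Oc4ccccc4)cc3)c2)c1`, gives 1870 nM
- compound 3, `COc1cc(C)cc(-c2nn(CC#N)cc2-c2ccnc(-c3ccc(N(C)C)cc3)c2)c1`, gives 681 nM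

Compound 3 holds the lowest number of the three in this assay. The nearest is compound 2, whose number is higher by a margin beyond the scatter, and compound 1 sits further away still. Compound 2 carries the hydroxy variant of the methylphenyl ring but differs from compound 3 in a second place as well, so its value alone says nothing about the methoxy-to-hydroxy change on its own.

Compound 4, `Cc1cc(O)cc(-c2nn(CC#N)cc2-c2ccnc(-c3ccc(N(C)C)cc3)c2)c1`, is compound 3 with hydrogen in place of methyl on an oxygen on an aromatic ring; cut one bond further out, this reads methoxy to hydroxy, or 3-methoxy-5-methylphenyl to 3-hydroxy-5-methylphenyl. Going by the values given here, no measured pair isolates this change. The expectation for the step of a 1.0-fold lower number from compound 3 to compound 4 (0.02 log units; within the scatter) is therefore one of no size beyond the scatter, with no preferred direction. Compound 4 is estimated at 650 nM in this assay, within a range from 250 nM to 1700 nM.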

Compound 4, concentration for 50% growth inhibition: 5130 nM
Compound 4: the middle estimate sits 7.9-fold (0.90 log units) below what was measured; measured number outside the range, above it.
By their numbers in this assay, from the lowest: compound 3; then compounds 2, 1 and 4 (each within the scatter of the next, the first and the last beyond it).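

In (this assay), the methyl on the oxygen now has an isolated reading: with the dimethylamino group held constant, methoxy to hydroxy gives (a 7.5-fold higher number from compound 3 to compound 4 (0.88 log units; beyond the scatter)). With the 3-hydroxy-5-methylphenyl ring held constant, dimethylamino in place of phenoxy also gives a higher number (a 2.7-fold higher number from compound 2 to compound 4 (0.44 log units; beyond the scatter)), so the low number of compound 3 is not carried by the dimethylamino group alone. Nothing available explains either step.

From the compounds shown here alone, only the dimethylamino pair isolates the methoxy-to-hydroxy change, so its size with phenoxy or the acetyl-bearing group in that other place remains open. Also open, going by these compounds, is how an ethoxy group or an amine would read in place of the methoxy.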